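Shortening the Ether Chain on a Eugenol-Type Agonist

The compounds below may be only part of what the source reports. "The series", "measured", "known", "first", "only" and "open" are said of these compounds alone.

The compounds here share a core that carries, on one side, a chain ether linking two aromatic parts. Compound 1 `C=CCc1cc(OC)c(OC(C)C(OCCCCCCCC)c2ccc(O)c(OC)c2)c(OC)c1` carries an octyloxy group at that position, and in an assay on HEK293 cells for agonist activity at transient receptor potential cation channel subfamily M member 8 (Homo sapiens), read by fluorescence and calcium flux, with a stated time of 5 min (on this read-out higher numbers stand for an effect only at larger amounts of compound and lower numbers for an effect already at smaller amounts), compound 1 gives 86 nM, the lowest of the three numbers measured. Compound 2 `C=CCc1cc(OC)c(O[C@H](C)[C@@H](OCC)c2ccc(O)c(OC)c2)c(OC)c1` and compound 3 `C=CCc1cc(OC)c(O[C@@H](C)[C@H](OCC)c2ccc(O)c(OC)c2)c(OC)c1` instead carry an ethoxy group and are mirror images of each other. In this assay compound 2 gives 1150 nM and compound 3 gives 1130 nM. Among the compounds with values here, the only measured step that changes one thing at a time, a 1.0-fold lower number from compound 2 to compound 3 (0.01 log units; within the scatter), arises from the fact that compounds 2 and 3 differ only in the configuration as drawn, so it says nothing about chain length. Compound 4 `C=CCc1cc(OC)c(OC(C)C(OCC(C)C)c2ccc(O)c(OC)c2)c(OC)c1` is the next to be measured; compared with compound 1 it differs by isopropyl in place of heptyl on a saturated chain carbon bound to an oxygen on a saturated carbon. Within the data shown here, no measured step covers this change; the values of compound 1 and of compounds 2 and 3 only show that a long ether chain sits at a lower number than a short one. Compound 4, with a chain of middle length, is therefore expected to land between them, giving a step of a 4.7-fold higher number from compound 1 to compound 4 (0.67 log units; beyond the scatter). The estimate for compound 4 is 400 nM, with a range from 150 nM to 1200 nM.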

Compound 4, half-maximal effective concentration: 138 nM
Compound 4: the middle estimate sits 2.9-fold (0.46 log units) above what was measured; the whole stated range lies above it.
By their numbers in this assay, from the lowest: compounds 1 and 4 (each within the scatter of the next); then compounds 3 and 2 (each within the scatter of the next).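

Going from octyloxy to isobutoxy removes much of the chain, yet it gives a 1.6-fold higher number from compound 1 to compound 4 (0.21 log units; within the scatter), so in this assay the two compounds cannot be told apart. The full octyl chain is therefore not needed for a number in this range, and a much shorter, branched chain serves equally well at this position. Nothing shown explains why the number holds up when the chain is cut back.

This single change both shortens and branches the chain, so the effects of length and branching remain unseparated, and a straight butyl chain would be the natural comparison. Also open, as far as these compounds go, is what a chain longer than octyl, or one ending in an amine or a carboxylic acid, would give at this position.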